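Another Aryl Group on the Aromatic Nitrogen

This account rests on a few compounds, and the source may have more. Where it says the series, first, only, none or still open, it means among the compounds named here.

For the measured compounds named here, in a functional assay on PC-12 cells (Rattus norvegicus) for cytotoxicity, read by MTT assay, with stated times of 2 h and 24 h, tested at 1 uM (a lower number here means a weaker effect, a higher number a stronger effect of the compound at the concentration tested), compound 2 `Oc1cc(C(F)(F)F)ccc1-c1nc(-c2ccccc2O)n(-c2ccc(F)cc2F)n1` gives 65.9%, while compound 1 `COc1ccccc1-n1nc(-c2ccc(C(F)(F)F)cc2O)nc1-c1ccccc1O` gives 70.7%, so the two numbers measured so far lie within the scatter of each other and neither can be called stronger or weaker. Going by the values given here, compound 3 `Cc1cc(C)cc(-n2nc(-c3ccc(C(F)(F)F)cc3O)nc2-c2ccccc2O)c1` has not yet been measured. 3,5-dimethylphenyl in place of 2,4-difluorophenyl on an aromatic nitrogen Only one measured step bears on this change: a number 4.8 percentage points lower from compound 1 to compound 2 (within the scatter), which also exchanged the group on an aromatic nitrogen and stayed within the scatter. With that single step as guide, the exchange leading to compound 3 is expected to produce no movement beyond the scatter in this assay. Compound 3 is therefore estimated to give 68%, within a range of 55% to 80%. The expected step is a number 2.1 percentage points higher from compound 2 to compound 3 (within the scatter), a change that is estimated to remain within the scatter.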

Compound 3, a percentage reported as activity, at one concentration (the size of the read-out at that concentration, not a potency): 76.9%
Compound 3: the middle estimate sits 8.9 percentage points below what was measured, and the stated range covers the measured number.
By their numbers in this assay, from the lowest: compounds 2, 1 and 3 (each within the scatter of the next, the first and the last beyond it).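

In this assay, for the compounds shown here, the group on the aromatic nitrogen now makes a readable difference: 3,5-dimethylphenyl in place of 2,4-difluorophenyl gives a number 11 percentage points higher from compound 2 to compound 3 (beyond the scatter), the only step at this position that leaves the scatter. With 3,5-dimethylphenyl in place of 2-methoxyphenyl the result is a number 6.2 percentage points higher from compound 1 to compound 3 (within the scatter), so 2-methoxyphenyl cannot be separated from either of the other two groups. No measurement at hand gives a reason for the step.

Going by these compounds, whether the rise goes with the two methyl groups themselves or with the loss of the two fluorines stays open, and a single methyl or a single fluorine on this aryl group would be needed to tell. Also open, on these data alone, is how an aryl group carrying an amine or a carboxylic acid, or a butyl chain in place of the aryl group, would read in this assay.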